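This account rests on a few compounds, and the source may have more. Where it says the series, first, only, none or still open, it means among the compounds named here.

Compound 1 `COc1cc(-c2cc(/C=C/C(=O)c3ccc(Cl)c(Cl)c3)[nH]n2)cc(OC)c1OC`: 8400 nM
Compound 2 `COc1ccc(-c2cc(/C=C/C(=O)c3ccc(N)cc3)[nH]n2)cc1OC`: 1500 nM
Compound 3 `COc1ccc(-c2cc(/C=C/C(=O)c3cc(OC)c(OC)c(OC)c3)[nH]n2)cc1OC`: 1360 nM

All three share a core and were tested in a functional assay on BT-549 cells (Homo sapiens) for inhibition, read by sulforhodamine B assay, with a stated time of 48 h; on this read-out higher numbers stand for weaker inhibition of growth and lower numbers for stronger inhibition of growth. Among them compound 1 gives the highest number, 8400 nM. Its nearest neighbour is compound 2 at 1500 nM, and the most distant is compound 3 at 1360 nM; both of these gaps are beyond the usual scatter, so compound 1 inhibits growth less strongly than either.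

The next compound, compound 4 `COc1ccc(C(=O)/C=C/c2cc(-c3cc(OC)c(OC)c(OC)c3)n[nH]2)cc1OC`, differs from compound 1 in one place: 3,4-dimethoxyphenyl in place of 3,4-dichlorophenyl on a carbonyl carbon. The 3,4-dichlorophenyl leaves and a 3,4-dimethoxyphenyl enters, on the carbonyl carbon whose other neighbour is a double-bonded chain carbon.

Within the data shown here, no step between measured compounds matches this change. Still, the two compounds with oxygen- or nitrogen-bearing aryl groups on the carbonyl, compound 2 and compound 3, both give lower numbers than compound 1. A step toward a lower number is therefore expected, beyond the scatter, from compound 1 to compound 4, estimated as a 4.2-fold lower number from compound 1 to compound 4 (0.62 log units; beyond the scatter). Compound 4 is expected to give about 2000 nM in this assay, within a range from 600 nM to 7000 nM.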

Compound 4, concentration for 50% growth inhibition: 1440 nM
For compound 4 the middle estimate is 1.4-fold (0.14 log units) above the measured one; measured number inside the range.
By their numbers in this assay, from the lowest: compounds 3, 4 and 2 (each within the scatter of the next); then compound 1.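

Among these compounds, on the carbonyl carbon, putting 3,4-dimethoxyphenyl in place of 3,4-dichlorophenyl gives a 5.8-fold lower number from compound 1 to compound 4 (0.77 log units; beyond the scatter) in this assay and so offers the first direct reading at this position, with the rest of the molecule held constant. The group on this carbon therefore affects growth inhibition, and the stronger inhibition here goes with the group that has two oxygen atoms and two hydrogen-bond acceptors instead of two chlorine atoms and none. No independent measurement explains why this swap changes the number. As far as these compounds go, it remains open whether both methoxy groups are needed or whether one methoxy group, a hydroxyl group or an amine on the ring would give a similar result. From the compounds shown here alone, it is also open whether a single chlorine atom would weaken inhibition as the pair in compound 1 does.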